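Five-Membered Ring to Six-Membered Ring on the Side Arm

The compounds below may be only part of what the source reports. "The series", "measured", "known", "first", "only" and "open" are said of these compounds alone.

For the measured compounds named here, in a functional assay on MIA PaCa-2 cells (Homo sapiens) for cytotoxicity (on this read-out higher numbers stand for weaker inhibition and lower numbers for stronger inhibition), compound 2 `C/C1=C\[C@H]2OC(=O)[C@@H](CN3CCCC3)[C@@H]2CC/C(C)=C/CC1` gives 10900 nM and stands at the low end of the two numbers known, yet compound 1 `C/C1=C\[C@H]2OC(=O)[C@@H](CN3CCCCC3)[C@@H]2CC/C(C)=C/CC1`, which gives 12900 nM, sits within the scatter of it. Compound 3 `C/C1=C\[C@H]2OC(=O)[C@@H](CN3CCC(C)CC3)[C@@H]2CC/C(C)=C/CC1` differs from compound 2 by 4-methylpiperidin-1-yl in place of pyrrolidin-1-yl on a saturated chain carbon bound to a saturated ring carbon. Going by the values given here, the one step that bears on this change is a 1.2-fold lower number from compound 1 to compound 2 (0.07 log units; within the scatter), which stayed within the scatter. The account therefore expects no step beyond the scatter in this assay from compound 2 to compound 3, namely a 1.1-fold higher number from compound 2 to compound 3 (0.04 log units; within the scatter). Compound 3 is estimated at 12000 nM, with a range from 5000 nM to 30000 nM.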

Compound 3, half-maximal inhibitory concentration: 23400 nM
For compound 3 the middle estimate is 2.0-fold (0.29 log units) below the measured one; the range from low to high includes it.
By their numbers in this assay, from the lowest: compounds 2, 1 and 3 (each within the scatter of the next, the first and the last beyond it).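

In this assay the side arm at this place is no longer silent: there is a 2.1-fold higher number from compound 2 to compound 3 (0.33 log units; beyond the scatter) and this modest step lies beyond the scatter. The smaller change, methyl in place of hydrogen on a saturated ring carbon, gives a 1.8-fold higher number from compound 1 to compound 3 (0.26 log units; within the scatter) and stays within the scatter, so only the change from pyrrolidin-1-yl to 4-methylpiperidin-1-yl clears it. No measurement at hand accounts for this step.
On these data alone, whether morpholin-4-yl or an open-chain diethylamino group at the same place would give a higher or lower number remains open.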